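A methoxy swap starting from a limit value

A few compounds are considered here, and "the series" means these few. Any claim that something is new, unique, unknown or untested is made for them only; others in the source may bear on it.

Measured so far in a functional assay on K562 cells (Homo sapiens) for antiproliferative activity, with a stated time of 72 h (on this read-out lower numbers stand for stronger inhibition and higher numbers for weaker inhibition), for two compounds
Compound 1 `OC[C@H]1O[C@@H](n2cnc3c(NCc4ccccc4F)ncnc32)[C@H](O)[C@@H]1O` gives 33200 nM
Compound 2 `Cc1cccc(CNc2ncnc3c2ncn3[C@@H]2O[C@H](CO)[C@@H](O)[C@H]2O)c1` gives > 166000 nM as a limit

Compound 2 stands at the limit of > 166000 nM in this assay, at which 1 of the 2 values shown sits, and this is a limit, not a number. Next comes compound 3 `COc1ccccc1CNc1ncnc2c1ncn2[C@@H]1O[C@H](CO)[C@@H](O)[C@H]1O` with the change 2-methoxyphenyl in place of 3-methylphenyl on a saturated chain carbon bound to a nitrogen on an aromatic ring that puts 2-methoxyphenyl in place of 3-methylphenyl on a saturated chain carbon bound to a nitrogen on an aromatic ring. Among the compounds with values here, one measured step bears on this place, namely an at least 5.0-fold higher number from compound 1 to compound 2 (0.69 log units; beyond the scatter) which lies beyond the scatter. Compound 1 carries 2-fluorophenyl and gives 33200 nM and the entering group carries the same number in its name, so a move back towards compound 1 is expected. The expected step is an at least 2.3-fold lower number from compound 2 to compound 3 (0.37 log units; beyond the scatter) in this assay towards a lower number. For compound 3 the estimate is 70000 nM with 25000 nM to 166000 nM as the expected range.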

Compound 3, half-maximal inhibitory concentration: 89000 nM
For compound 3 the middle estimate is 1.3-fold (0.10 log units) below the measured one; the range from low to high includes it.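

Methoxy in place of fluoro on an aromatic carbon gives a 2.7-fold higher number from compound 1 to compound 3 (0.43 log units; beyond the scatter), the first step at this place in this assay read between two measured numbers. On these data alone, the step to 2-methoxyphenyl reads as an at least 1.8-fold lower number from compound 2 to compound 3 (0.27 log units; that floor lies within the scatter), so its true size stays unknown and it may not exceed the usual scatter. Compound 2 has only a limit: the limit of > 166000 nM in this assay, at which 1 of the 3 values shown sits.

The compounds shown leave open how 2-chlorophenyl would compare with 2-fluorophenyl and 2-methoxyphenyl. They also leave open what a longer chain ending in an amine would do at this place.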